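Opening the Amine Ring on the Shared Core

The compounds below may be only part of what the source reports. "The series", "measured", "known", "first", "only" and "open" are said of these compounds alone.

Of the compounds shown here, three built on one shared core have been tested in an assay on isolated protein for inhibition of DNA topoisomerase 1 (Homo sapiens), with a stated time of 15 min; a lower number here means a stronger inhibitor, a higher number a weaker inhibitor. Compound 1 `CN[C@@H]1CCN(c2cc3c(cc2F)c(=O)c(C(=O)O)cn3Cc2ccc(-c3ccccc3)cc2)C1` gives 34800 nM. Compound 2 `COc1c(N2CC[C@@H](N)C2)c(F)cc2c(=O)c(C(=O)O)cn(Cc3ccc(-c4ccccc4)cc3)c12` gives 92200 nM in this assay, and compound 3 `O=C(O)c1cn(Cc2ccc(-n3cccn3)cc2)c2cc(NC[C@@H]3CCNC3)c(F)cc2c1=O` gives 200000 nM. Compound 1 thus holds the lowest number of the three; compound 2 stands above it by a step beyond the usual scatter, and compound 3 stands further away still. Even so, all three numbers describe weak inhibition, and the set so far covers only a narrow band of weak activity.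

Compound 4 `CNCCCCNc1cc2c(cc1F)c(=O)c(C(=O)O)cn2Cc1ccc(-c2ccccc2)cc1` has not yet been measured in this assay. It differs from compound 1 in one place: (4-(methylamino)butyl)amino in place of 3-(methylamino)pyrrolidin-1-yl on an aromatic carbon. The side group keeps its count of heavy atoms, loses its ring and gains one hydrogen-bond donor. Among the compounds with values here, no measured pair isolates a change of this kind, and compound 3, the only one carrying an open link to its amine, also differs elsewhere, so it offers no clean comparison. Without such a step, the expectation stays close to compound 1: compound 4 is expected to sit near it, with a 1.4-fold higher number from compound 1 to compound 4 (0.16 log units; within the scatter) estimated as a small rise that may not exceed the scatter. Compound 4 is estimated at 50000 nM, within a range from 15000 nM to 200000 nM.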

Compound 4, half-maximal inhibitory concentration: 88300 nM
Compound 4: the middle estimate sits 1.8-fold (0.25 log units) below what was measured; measured number inside the range.
By their numbers in this assay, from the lowest: compound 1; then compounds 4 and 2 (each within the scatter of the next); then compound 3.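

In this assay, within the data shown here, the first comparison that changes only this position, (4-(methylamino)butyl)amino in place of 3-(methylamino)pyrrolidin-1-yl on the aromatic carbon ortho to a fluoro group, gives a 2.5-fold higher number from compound 1 to compound 4 (0.40 log units; beyond the scatter) and so shows that this side group responds modestly to opening the ring. Both groups hold the same count of heavy atoms, yet the ring and the defined stereocentre leave and a hydrogen-bond donor enters, so the step reflects these differences taken together rather than any one of them. No measurement shown here explains the rise in the number, and none says which of these differences matters.

Among these compounds, the single step cannot separate the loss of the ring from the added donor, and it cannot show whether the length of the chain matters. A shorter propyl chain, a longer hexyl chain or a dimethylamino group at the chain end could each test this position further, while a piperidine ring in place of the pyrrolidine could show whether ring size matters at this carbon.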